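The compounds below may be only part of what the source reports. "The series", "measured", "known", "first", "only" and "open" are said of these compounds alone.

In a functional assay on CCRF-CEM cells (Homo sapiens) for antiproliferative activity, read by fluorescence and resazurin assay, with a stated time of 48 h (on this read-out higher numbers stand for weaker inhibition and lower numbers for stronger inhibition), compound 1 `Cc1noc(NS(=O)(=O)c2ccc(NC(=O)c3cc4ccc(O)cc4oc3=O)cc2)c1C` gives 21500 nM and compound 2 `CCOc1ccc2nc(Cl)c(/C=N/NC(=O)c3cc4cc([N+](=O)[O-])ccc4oc3=O)cc2c1` gives 15700 nM and these two numbers lie within the usual scatter of each other. Compound 3 `CCOc1ccc2nc(Cl)c(/C=N/NC(=O)c3cc4ccccc4oc3=O)cc2c1` differs from compound 2 in one place hydrogen in place of nitro on an aromatic carbon with hydrogen in place of nitro on an aromatic carbon. Among the measured compounds shown here, no pair of measured compounds shows this change, so no step beyond the scatter is expected in either direction. The estimated step of a 1.1-fold higher number from compound 2 to compound 3 (0.03 log units; within the scatter) is accordingly small. In this assay compound 3 is expected at 17000 nM with an estimated span from 6000 nM to 45000 nM as its likely range.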

Compound 3, half-maximal inhibitory concentration: 6320 nM
Estimate against measurement, compound 3: 2.7-fold (0.43 log units) above, within the range that was stated.
By their numbers in this assay, from the lowest: compound 3; then compounds 2 and 1 (each within the scatter of the next).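

Going from nitro to hydrogen on this aromatic carbon of the fused ring system gives a 2.5-fold lower number from compound 2 to compound 3 (0.40 log units; beyond the scatter) in this assay, so what this carbon carries does affect the read-out, and the nitro group is not needed for antiproliferative activity in this series. The lower number comes with the plain hydrogen, which carries no heavy atom at all. Nothing measured here explains the step. As far as these compounds go, only nitro and hydrogen appear at this carbon, so it stays open how an amine or a methoxy group would fare there. A single pair also cannot show whether the same change would hold on a different core.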